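The source may hold more compounds than are shown below. What is called first, only, known or untested is meant among the compounds shown, and "the series" means these compounds.

Measured so far in a functional assay on U-373MG ATCC cells (Homo sapiens) for inhibition, read by MTT assay, with a stated time of 72 h; a lower number here means a stronger inhibitor, a higher number a weaker inhibitor:
- compound 1 `CC1(C)CC(NC(=O)Nc2cccc(Cl)c2)c2cc(Br)ccc2O1` gives 69000 nM
- compound 2 `CC1(C)CC(NC(=O)NCc2ccccc2)c2cc(Br)ccc2O1` gives 27000 nM
- compound 3 `CC1(C)CC(NC(=O)Nc2ccccc2Cl)c2cc(Cl)ccc2O1` gives 17000 nM

Compound 3 lies within the scatter of compound 2 and has a clearly lower number than compound 1, so it stands with compound 2 at the lower end of this small set. Compound 4 `CC1(C)CC(NC(=O)Nc2ccccc2Cl)c2cc(Br)ccc2O1` differs from compound 3 by a single exchange (bromo in place of chloro on an aromatic carbon), bromo in place of chloro on an aromatic carbon.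

Among the measured compounds shown here, no measured step makes this exchange. For the measured compounds named here, the only step available, a 2.6-fold lower number from compound 1 to compound 2 (0.41 log units; beyond the scatter), is a modest one, with benzyl in place of 3-chlorophenyl on an amide-type nitrogen, which is a different place in the structure. Compound 1 and compound 2 carry bromo where compound 3 carries chloro, but they also differ from it on that nitrogen, so their values do not isolate the exchange.

In this assay no step beyond the scatter is therefore expected, and the expectation starts from compound 3 at 17000 nM in this assay. The expected change is a 1.2-fold higher number from compound 3 to compound 4 (0.07 log units; within the scatter) in size. Compound 4 is estimated at 20000 nM, within an expected range of 8000 nM to 50000 nM in this assay.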

Compound 4, half-maximal inhibitory concentration: 19000 nM
Compound 4: middle estimate off by 1.1-fold (0.02 log units), on the high side; measured number inside the range.
By their numbers in this assay, from the lowest: compounds 3, 4 and 2 (each within the scatter of the next); then compound 1.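

In this assay, the direct step of a 1.1-fold higher number from compound 3 to compound 4 (0.05 log units; within the scatter) shows that bromo in place of chloro on this aromatic carbon leaves the number within the scatter, so the two halogens cannot be told apart at this position. With bromo held fixed, a 1.4-fold lower number from compound 2 to compound 4 (0.15 log units; within the scatter) likewise does not separate 2-chlorophenyl from benzyl on the amide-type nitrogen, whereas a 3.6-fold lower number from compound 1 to compound 4 (0.56 log units; beyond the scatter) is a modest step beyond the scatter that separates 2-chlorophenyl from 3-chlorophenyl. No measurement is available that accounts for any of these steps.

The compounds shown leave open whether this aromatic carbon tolerates anything other than a halogen, such as a methoxy group, a nitrile or a plain hydrogen. They also leave open how an amine or a carboxylic acid on the phenyl ring of the nitrogen substituent would read.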